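A few compounds are considered here, and "the series" means these few. Any claim that something is new, unique, unknown or untested is made for them only; others in the source may bear on it.

Measured so far in an ADME assay on Vero cells (Chlorocebus sabaeus) for cytotoxicity, with a stated time of 7 days; on this read-out lower numbers stand for higher toxicity in this test and higher numbers for lower toxicity in this test:

compound 1 `COc1ccc2[nH]c(C(=O)N3CC(=O)N(Cc4ccccc4)[C@@H](CCc4ccccc4)C3)cc2c1`: compound 1 gives > 30000 nM, a limit of the assay
compound 2 `COc1ccc2[nH]c(C(=O)N3CC(=O)N(Cc4ccccc4)[C@@H](N4CCc5ccccc54)C3)cc2c1`: compound 2 gives > 100000 nM, a limit of the assay
compound 3 `COc1ccc2[nH]c(C(=O)N3CC(=O)N(Cc4ccccc4)[C@@H](CN4CCC(C(C)C)CC4)C3)cc2c1`: compound 3 gives 3800 nM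

Among the compounds with values here, compound 3 carries the only number in the set; the other two values are limits. From compound 1 the step reads an at least 7.8-fold lower number from compound 1 to compound 3 (0.89 log units; beyond the scatter), and from compound 2 it reads an at least 26-fold lower number from compound 2 to compound 3 (1.42 log units; beyond the scatter). The pair of limits gives a step that the two limits leave unreadable from compound 1 to compound 2, which is not readable in size.

Compound 4 `COc1ccc2[nH]c(C(=O)N3CC(=O)N(Cc4ccccc4)[C@@H](CN4CCn5cccc5C4)C3)cc2c1` differs from compound 3 by a group of 9 heavy atoms (7 carbon, 2 nitrogen; one five-membered aromatic ring with 1 hetero atom, one six-membered non-aromatic ring with 2 hetero atoms) in place of a group of 9 heavy atoms (8 carbon, 1 nitrogen; one six-membered non-aromatic ring with 1 hetero atom), on a saturated chain carbon bound to a saturated ring carbon. Within the data shown here, none of the measured steps exchanges one ring-bearing amine group for another at this place, so they bear only loosely on the change: both steps that arrive at compound 3 moved from a limit to a number, and nothing shows what a further group of the same size does. The expected step of a 1.8-fold higher number from compound 3 to compound 4 (0.27 log units; within the scatter) is therefore small, toward a higher number in this assay, with wide uncertainty. The estimate for compound 4 in this assay is 7000 nM, within 2000 nM to 30000 nM.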

Compound 4, half-maximal cytotoxic concentration: > 100000 nM
Compound 4 gave a limit, no number (the forecaster's own chance of this, stated with the estimate: 25%); middle value at least 14-fold (1.15 log units) away from the limit.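

At the saturated chain carbon bound to a saturated ring carbon, the identity of the group matters even when the heavy-atom count stays the same: in this assay, replacing 4-isopropylpiperidin-1-yl with the group bearing the five-membered aromatic ring gives an at least 26-fold higher number from compound 3 to compound 4 (1.42 log units; beyond the scatter). Compound 4 gives a limit, not a number, and a second ring-bearing amine group at this place therefore does not reproduce the number seen with compound 3: the limit of > 100000 nM in this assay, at which 2 of the 4 values shown sit. The steps joining compound 4 to compound 1 and compound 2 link two limits and cannot be read.

Which part of 4-isopropylpiperidin-1-yl goes with the lower number stays open. An unsubstituted piperidine or a morpholine at the same place would test whether the isopropyl group or the piperidine ring tracks with it.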